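Sulfonamide variation on the compound 1 core for alpha-2B

A few compounds are considered here, and "the series" means these few. Any claim that something is new, unique, unknown or untested is made for them only; others in the source may bear on it.

Measured compounds:
compound 1, `CCS(=O)(=O)Nc1cccc2c1CCCC2c1c[nH]cn1`: 1700 nM
compound 2, `CCS(=O)(=O)Nc1cccc2c1CCC2c1c[nH]cn1`: 186 nM

In an assay on isolated protein for binding affinity to Alpha-2B adrenergic receptor (Rattus norvegicus), read by radioligand binding (on this read-out lower numbers stand for stronger inhibition and higher numbers for weaker inhibition), compound 1 gives 1700 nM, the higher of the two numbers in hand. Compound 2 gives 186 nM in this assay, a lower number, and the gap to compound 1 lies beyond the scatter. Within the data shown here, no pair of measured compounds differs in one place only, so no measured step bears directly on a change of the sulfonamide.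

Compound 3 `CN(c1cccc2c1CCCC2c1c[nH]cn1)S(C)(=O)=O` is not yet measured. It differs from compound 1 as follows: methyl(methylsulfonyl)amino in place of (ethylsulfonyl)amino on an aromatic carbon. With nothing measured for a change of this kind, the step in this assay from compound 1 to compound 3 is expected to be modest and toward a higher number, about a 2.1-fold higher number from compound 1 to compound 3 (0.31 log units; beyond the scatter). Compound 3 is therefore estimated at 3500 nM, with a range from 900 nM to 14000 nM.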

Compound 3, inhibition constant: 912 nM
The estimate for compound 3 lay 3.8-fold (0.58 log units) above the measured number, within the range that was stated.
By their numbers in this assay, from the lowest: compound 2; then compounds 3 and 1 (each within the scatter of the next).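

In this assay the exchange of (ethylsulfonyl)amino for methyl(methylsulfonyl)amino on an aromatic carbon gives a 1.9-fold lower number from compound 1 to compound 3 (0.27 log units; within the scatter), so compound 1 and compound 3 cannot be told apart at this position. The two groups have the same atoms joined differently, and the entering group has 0 hydrogen-bond donors where the leaving group has 1 hydrogen-bond donor, so on the core of compound 1 the read-out does not depend on that donor. Nothing measured on these compounds accounts for this result.

The step alters the group on nitrogen and the chain on sulfur together, and methyl(ethylsulfonyl)amino or (methylsulfonyl)amino on the same core would separate the two. As far as these compounds go, a longer chain on the sulfonyl, such as propyl, and the same exchange on the core of compound 2 remain open.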